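The source may report more compounds than this note shows. Statements on the series, on what has been measured and on what is new or still open speak of the compounds shown alone.

Compound 2 `COc1ccccc1CNC1(CCC(C)(C)C)C(=O)C(C2=NS(=O)(=O)c3cc(NS(C)(=O)=O)ccc3N2)=C(O)c2ccccc21` carries a 2-methoxybenzyl group on the amine nitrogen of the shared core. Among the measured compounds shown here, in an in vivo ADME assay on the whole organism (strain Sprague-Dawley) for metabolic stability, with Rattus norvegicus as the target, at a dose of 5 mg/kg by the intravenous route (on this read-out higher numbers stand for a longer-lived compound and lower numbers for a shorter-lived compound), compound 2 gives 3.2 h, one of only two numbers measured, and compound 1 `CC(C)(C)CCC1(NCc2ccc3ccccc3c2)C(=O)C(C2=NS(=O)(=O)c3cc(NS(C)(=O)=O)ccc3N2)=C(O)c2ccccc21` gives 2.2 h in this assay, a step within the scatter separating the two. For the measured compounds named here, the single measured step, a 1.5-fold higher number from compound 1 to compound 2 (0.16 log units; within the scatter), exchanges one aryl group for another at the same place and stays within the scatter. Compound 3 `Cc1cccc(C)c1CNC1(CCC(C)(C)C)C(=O)C(C2=NS(=O)(=O)c3cc(NS(C)(=O)=O)ccc3N2)=C(O)c2ccccc21` is not yet measured; it differs from compound 2 by 2,6-dimethylphenyl in place of 2-methoxyphenyl on a saturated chain carbon bound to an amine nitrogen. Going by the values given here, only the step from compound 1 to compound 2 bears on this change, and its size gives no ground for expecting a shift beyond the scatter in this assay. Compound 3 is therefore expected to give about 3 h, with a range from 1.5 h to 6 h. The step this estimate means, a 1.1-fold lower number from compound 2 to compound 3 (0.03 log units; within the scatter), is expected to lie within the scatter.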

Compound 3, half-life: 5 h
Estimate against measurement, compound 3: 1.7-fold (0.22 log units) below; low and high end bracket the measured number.
By their numbers in this assay, from the lowest: compounds 1, 2 and 3 (each within the scatter of the next, the first and the last beyond it).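

In this assay, the exchange of 2-methoxyphenyl for 2,6-dimethylphenyl on a saturated chain carbon bound to an amine nitrogen gives a 1.6-fold higher number from compound 2 to compound 3 (0.19 log units; within the scatter), so a second aryl exchange at this place also stays inside the scatter, this time with an aryl group that carries two methyl groups and no oxygen. Among the compounds shown here, the wider comparison gives a 2.3-fold higher number from compound 1 to compound 3 (0.36 log units; beyond the scatter), the first step at this place to pass beyond the scatter, though a modest one, and it shows that the choice of aryl group here can register in half-life. The data offer nothing that explains either step. Open, as far as these compounds go, is how half-life responds when a pyridine ring or a cyclohexyl ring stands at this place. Also open, from the compounds shown here alone, is whether a single methyl group on the phenyl ring gives a half-life like that of compound 3.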